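This account rests on a few compounds, and the source may have more. Where it says the series, first, only, none or still open, it means among the compounds named here.

Working notes on the series.

The shared core carries a thioaryl group at one end and a variable substituent at the other. Compound 1 `COc1ccc(OC)c(Sc2ccc3nnc(-c4ccccn4)n3n2)c1` bears a pyridinyl group there and in an assay on HEK293 cells for inhibition of Leucine-rich repeat serine/threonine-protein kinase 2 (Homo sapiens), read by ELISA, with a stated time of 90 min (a lower number here means a stronger inhibitor, a higher number a weaker inhibitor), compound 1 gives 1310 nM. Compound 2 `COc1ccc(OC)c(Sc2ccc3nnc(C4CCN(C)C4)n3n2)c1` and compound 3 `COc1ccc(OC)c(Sc2ccc3nnc(Cc4cnn(C)c4)n3n2)c1` vary the same position, but neither has a reported result in this assay. In this assay compound 2 is recorded as "not determined" (no result reported). In this assay compound 3 is recorded as "not determined" (no result reported). Compound 3 therefore stands without a number, and compound 2 is likewise without one, so the series holds a single measured value in all.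

Compound 4 `COc1ccc(OC)c(Sc2ccc3nnc(-c4cn(C)nc4C)n3n2)c1` differs from compound 3 by a rearrangement of the same atoms: 1,3-dimethyl-1H-pyrazol-4-yl in place of (1-methyl-1H-pyrazol-4-yl)methyl on an aromatic carbon. Among the measured compounds shown here, no measured step joins the two, so the size of this step in this assay cannot be read from data; the direction is open, and a step within the usual scatter is as plausible as one beyond it. For the measured compounds named here, the only anchor is compound 1 with a directly attached aromatic ring, which in this assay gives 1310 nM.

On that basis compound 4 is expected to give about 1000 nM in this assay, with a range of 200 nM to 6000 nM.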

Compound 4, half-maximal inhibitory concentration: 1260 nM
For compound 4 the middle estimate is 1.3-fold (0.10 log units) below the measured one; the range from low to high includes it.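

Among the compounds shown here, the first readable step at this position is a 1.0-fold lower number from compound 1 to compound 4 (0.02 log units; within the scatter), and it stays within the scatter in this assay. With a directly attached ring, 1,3-dimethyl-1H-pyrazol-4-yl and pyridin-2-yl therefore cannot be told apart in this assay, although one is a five-membered and the other a six-membered aromatic ring, so this single exchange leaves the read-out unchanged. No supporting measurement is available to explain this result.

Steps to compound 2 and compound 3 cannot be read, so it remains open whether a ring held through a methylene link, as in (1-methyl-1H-pyrazol-4-yl)methyl, differs from a directly attached one. Also open, as far as these compounds go, is how a carboxylic acid, a primary amine or a longer alkyl chain at this position would behave in this assay.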